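Ethoxy for Ethylamino on a Carbonyl Carbon: Compound 3 to Compound 4

The compounds below may be only part of what the source reports. "The series", "measured", "known", "first", "only" and "open" are said of these compounds alone.

The measured compounds:
compound 1 `Cn1cncc1CN1CC(N(CC2CCN(C(=O)CNC(=O)OC(C)(C)C)CC2)S(=O)(=O)c2ccccn2)Cc2cc(C#N)ccc21` — 0.5 10^-6 cm/s in an ADME assay on Caco-2 cells (Homo sapiens) for permeability, in the apical to basolateral direction; a lower number here means that the compound crosses the layer more slowly, a higher number that the compound crosses the layer faster
compound 2 `Cn1cncc1CN1CC(N(CC2CCN(C(=O)OC(C)(C)C)CC2)S(=O)(=O)c2ccccn2)Cc2cc(C#N)ccc21` — 15.5 10^-6 cm/s in this assay
compound 3 `CCNC(=O)N1CCC(CN(C2Cc3cc(C#N)ccc3N(Cc3cncn3C)C2)S(=O)(=O)c2ccccn2)CC1` — 0.6 10^-6 cm/s in this assay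

Among these three numbers, compound 3 stands second highest. It sits close to compound 1, with a 1.2-fold higher number from compound 1 to compound 3 (0.08 log units; within the scatter), and far from compound 2, with a 26-fold lower number from compound 2 to compound 3 (1.41 log units; beyond the scatter). Compound 4 `CCOC(=O)N1CCC(CN(C2Cc3cc(C#N)ccc3N(Cc3cncn3C)C2)S(=O)(=O)c2ccccn2)CC1` has not yet been measured. It differs from compound 3 in one place: ethoxy in place of ethylamino on a carbonyl carbon.

Going by the values given here, two measured steps bear on this change. The step of a 26-fold lower number from compound 2 to compound 3 (1.41 log units; beyond the scatter) is the same kind of exchange run in reverse, from tert-butoxy to ethylamino rather than from ethylamino to ethoxy. The step of a 31-fold higher number from compound 1 to compound 2 (1.49 log units; beyond the scatter) likewise arrives at an alkoxy group on a carbonyl carbon. Both steps are large and both point the same way, so a large upward step is expected for compound 4 in this assay, though whether an ethoxy group reaches the level seen with tert-butoxy in compound 2 cannot be read from these three compounds.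

Compound 4 is therefore expected to give about 8 10^-6 cm/s in this assay, within a likely range from 3 10^-6 cm/s to 20 10^-6 cm/s. The expected step is a 13-fold higher number from compound 3 to compound 4 (1.12 log units; beyond the scatter).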

Compound 4, apparent permeability: 2.6 10^-6 cm/s
Beside the measured number, compound 4's estimate is 3.1-fold (0.49 log units) above it; the whole stated range lies above it.
By their numbers in this assay, from the lowest: compounds 1 and 3 (each within the scatter of the next); then compound 4; then compound 2.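

The exchange of ethylamino for ethoxy on this carbonyl carbon, which takes away the hydrogen-bond donor of the leaving group, has a real but not large effect in this assay, with a 4.3-fold higher number from compound 3 to compound 4 (0.64 log units; beyond the scatter). The group on the oxygen matters as well, since ethyl in place of tert-butyl gives a 6.0-fold lower number from compound 2 to compound 4 (0.78 log units; beyond the scatter), so the large gap of a 26-fold lower number from compound 2 to compound 3 (1.41 log units; beyond the scatter) is now divided into two modest steps, one for the exchange of ethylamino for ethoxy and one for the change of the alkyl group on the oxygen. Ethoxy also stands clear of the ((tert-butoxycarbonyl)amino)methyl group of compound 1, with a 5.2-fold higher number from compound 1 to compound 4 (0.72 log units; beyond the scatter), which places compound 4 in the middle, apart from both compound 2 and the pair of compound 1 and compound 3.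

Nothing shown here gives a measured explanation for any of these steps. As far as these compounds go, it remains open whether a tert-butylamino group on the same carbonyl carbon would lie as far below tert-butoxy as ethylamino lies below ethoxy, and where a methoxy group or a longer chain such as propoxy would fall.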